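Aryl keto-acid series: chloro to methyl exchange

The source may hold more compounds than are shown below. What is called first, only, known or untested is meant among the compounds shown, and "the series" means these compounds.

Measured so far in a functional assay on HeLa cells (Homo sapiens) for inhibition, read by MTT assay, with a stated time of 72 h; on this read-out higher numbers stand for weaker inhibition and lower numbers for stronger inhibition:
compound 1 `O=C(O)/C=C/C(=O)c1ccc(Cl)cc1Cl`: 62900 nM
compound 2 `O=C(O)/C=C/C(=O)c1ccc(Cl)cc1`: 25400 nM

Going by the values given here, compound 1 stands with the highest of the two numbers; its nearest neighbour is compound 2, and the step of a 2.5-fold lower number from compound 1 to compound 2 (0.39 log units; beyond the scatter) was the sole measured step in the set. That step removed a chloro from an aromatic carbon of the shared core and brought a modest drop in the number.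

Compound 3 `Cc1ccc(C(=O)/C=C/C(=O)O)c(Cl)c1` is still to be measured. Against compound 1 it shows (methyl in place of chloro on an aromatic carbon), the exchange sitting para to a group of 7 heavy atoms and meta to a chloro group. Among the compounds with values here, no measured step touches that carbon, so the step to compound 2 is only a loose guide: it suggests that removing chlorine at this core is tolerated, and its size is the best measure available. A similar or smaller step, most likely towards a lower number, is therefore expected for compound 3, and the estimate for compound 3 in this assay is 40000 nM, spanning 15000 nM to 100000 nM, which would mean a step of a 1.6-fold lower number from compound 1 to compound 3 (0.20 log units; within the scatter).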

Compound 3, half-maximal inhibitory concentration: 7600 nM
The estimate for compound 3 lay 5.3-fold (0.72 log units) above the measured number; the whole stated range lies above it.
By their numbers in this assay, from the lowest: compound 3; then compound 2; then compound 1.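

The carbon para to a group of 7 heavy atoms proves responsive in this assay: methyl in place of chloro there gives (an 8.3-fold lower number from compound 1 to compound 3 (0.92 log units; beyond the scatter)), with the chloro meta to it kept. Going by these compounds alone, this step is the first to touch this carbon, and it shows that chloro is not needed there for a lower number; it also exceeds the step at the other chloro-bearing carbon (a 2.5-fold lower number from compound 1 to compound 2 (0.39 log units; beyond the scatter)), so the two carbons of the shared core do not respond alike. The data on hand offer no measured basis for explaining the step.

Open, going by these compounds, is whether methyl itself matters or only the departure of chloro, which a hydrogen, an ethyl chain or a methoxy group at this carbon would help separate. Also open, on these data alone, is whether methyl gives a step of like size when the remaining chloro is exchanged for hydrogen.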